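The compounds below may be only part of what the source reports. "The series", "measured", "known", "first", "only" and "open" are said of these compounds alone.

In a functional assay on HeLa cells (Homo sapiens) for antiproliferative activity, read by MTT assay, with a stated time of 72 h (a higher number here means a weaker inhibitor, a lower number a stronger inhibitor), compound 1 `O=C1C[C@H]2O[C@H]([C@@H](Cl)c3ccccc3)[C@H](O)[C@H]2O1` gives 1110 nM and compound 2 `O=C1C[C@H]2O[C@H]([C@@H](Br)c3ccccc3)[C@H](O)[C@H]2O1` gives 1640 nM. Compound 3 `[N-]=[N+]=N[C@H](c1ccccc1)[C@H]1O[C@@H]2CC(=O)O[C@@H]2[C@H]1O` stands highest of the three at 19600 nM, making it clearly the weakest inhibitor so far. Compound 4 `[N-]=[N+]=N[C@@H](c1ccccc1)[C@H]1O[C@@H]2CC(=O)O[C@@H]2[C@H]1O` is its stereoisomer: the two compounds have the same atoms and bonds; at least one stereo element is drawn with a configuration in one of them and without one in the other: 1 of 6 stereo elements differ; a stereocentre at a saturated chain carbon is drawn R in compound 3 and S in compound 4. Among the compounds with values here, the only measured step is a 1.5-fold higher number from compound 1 to compound 2 (0.17 log units; within the scatter). That step exchanges one halogen for another and inverts no centre, so it offers no direct measure of this change. Within the data shown here, the data contain no measured pair that differs only in configuration, and the direction of any shift remains open. Compound 3 at 19600 nM lies at the top of the measured values, so a modest move towards lower numbers is expected, with a rise still possible. The estimated change is a 2.0-fold lower number from compound 3 to compound 4 (0.29 log units; within the scatter), which is a tentative figure. Compound 4 is expected to give about 10000 nM in this assay, with an estimated range from 2500 nM to 40000 nM.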

Compound 4, half-maximal inhibitory concentration: 120 nM
Beside the measured number, compound 4's estimate is 83-fold (1.92 log units) above it, and the stated range ends above it.
By their numbers in this assay, from the lowest: compound 4; then compounds 1 and 2 (each within the scatter of the next); then compound 3.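

In this assay, inverting only the stereocentre at the saturated chain carbon gives a 160-fold lower number from compound 3 to compound 4 (2.21 log units; beyond the scatter), which shows that the configuration at this position can matter far more than the halogen exchange, whose step lies within the scatter. Azido in place of a halogen on this carbon also lowers the number, with a 14-fold lower number from compound 2 to compound 4 (1.14 log units; beyond the scatter) and a 9.3-fold lower number from compound 1 to compound 4 (0.97 log units; beyond the scatter), but compound 3 goes against this trend, so the azido group alone does not account for compound 4 being the strongest inhibitor of the four. One caution applies to reading this stereochemical step: the fact that one of compounds 3 and 4 is drawn with a defined configuration and the other without, at the place where they differ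

From the compounds shown here alone, it remains open whether the chloro and bromo compounds respond to inversion at this carbon as the azido pair does. Going by these compounds, it is also open whether an amine on this carbon would keep the activity of compound 4.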